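A few compounds are considered here, and "the series" means these few. Any claim that something is new, unique, unknown or untested is made for them only; others in the source may bear on it.

Measured in an ADME assay on HEK293 cells (Homo sapiens) for cytotoxicity, read by reporter gene assay and resazurin assay, with a stated time of 48 h; a higher number here means that more compound is tolerated, a lower number that less compound is tolerated:
compound 1 `COc1ccc(Br)cc1C(=O)Nc1ccc(Sc2nc3ccccc3s2)cc1`: > 100000 nM (a limit)
compound 2 `O=C(Nc1ccc(Sc2nc3ccccc3s2)c(Cl)c1)c1cc(Br)cc(Br)c1O`: 76000 nM
compound 3 `O=C(Nc1ccc(Sc2nc3ccccc3s2)c(Cl)c1)c1ccccc1O`: 64000 nM

Compound 3, at 64000 nM, stands level with compound 2, at 76000 nM: the two numbers lie within the scatter of each other. The next compound to be tested is compound 4 `COc1ccc(Br)cc1C(=O)Nc1ccc(Sc2nc3ccccc3s2)c(Cl)c1`. It differs from compound 3 as follows: 5-bromo-2-methoxyphenyl in place of 2-hydroxyphenyl on a carbonyl carbon. In words, 5-bromo-2-methoxyphenyl stands in place of 2-hydroxyphenyl on a carbonyl carbon.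

Two observations bear on this change. Among the compounds with values here, the only measured step also changes the group on the carbonyl carbon: a 1.2-fold lower number from compound 2 to compound 3 (0.07 log units; within the scatter). It stays within the scatter, although it is a different change from the one now in question.

The value of compound 1, which carries the same 5-bromo-2-methoxyphenyl on the core of compound 1, is a limit: > 100000 nM.

Within the data shown here, no step between that compound and compound 4 has been measured. In this assay, no step beyond the scatter is therefore expected, with any small drift towards more compound tolerated. The expected step is a 1.3-fold higher number from compound 3 to compound 4 (0.10 log units; within the scatter). For compound 4 the estimate is 80000 nM, with an expected range of 40000 nM to 100000 nM.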

Compound 4, half-maximal cytotoxic concentration: > 100000 nM
Compound 4: a limit, no number; the forecaster's own chance of this, stated with the estimate: 30%; at least 1.2-fold (0.09 log units) between middle value and limit.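

The 5-bromo-2-methoxyphenyl group on the carbonyl carbon gives an at least 1.5-fold higher number from compound 3 to compound 4 (0.19 log units; that floor lies within the scatter), and in place of 3,5-dibromo-2-hydroxyphenyl it gives an at least 1.3-fold higher number from compound 2 to compound 4 (0.11 log units; that floor lies within the scatter). In this assay compound 4 gives > 100000 nM, which is a limit and not a number, so both steps are floors, and the true sizes may be larger than those floors. New here is that the two compounds carrying 5-bromo-2-methoxyphenyl, compound 1 and compound 4, both sit at the limit, with and without the chloro, while compound 2 and compound 3, with their hydroxyphenyl groups, give numbers: the limit of > 100000 nM in this assay, at which 2 of the 4 values shown sit.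

As far as these compounds go, compound 1 and compound 4 both carry limits, so the step for chloro in place of hydrogen on an aromatic carbon cannot be read, and how far either compound lies past the limit stays unknown. Also open, from the compounds shown here alone, is which part of the entering group goes with the limit, a question that a plain 2-methoxyphenyl or a 5-bromo-2-hydroxyphenyl on the carbonyl carbon would address, as is whether an amine or a carboxylic acid on that ring would give a number again.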